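Sulfonamide CCR9 antagonists: swapping the pyridine substituent

This account rests on a few compounds, and the source may have more. Where it says the series, first, only, none or still open, it means among the compounds named here.

Measured compounds:
Compound 1 `COc1cccnc1-c1cc(Cl)ccc1NS(=O)(=O)c1ccc(C(C)(C)C)cc1`: 958 nM
Compound 2 `CC(C)(C)c1ccc(S(=O)(=O)Nc2ccc(Cl)cc2-c2ncccc2N)cc1`: 95 nM
Compound 3 `CC(C)(C)c1ccc(S(=O)(=O)Nc2ccc(Cl)cc2-c2ncccc2CN)cc1`: 3160 nM

The three compounds share a core and differ only in the group carried on the six-membered aromatic ring with one hetero atom. In a functional assay on isolated protein for antagonist activity at C-C chemokine receptor type 9 (Homo sapiens), read by calcium flux, with a stated time of 10 min (on this read-out higher numbers stand for weaker inhibition and lower numbers for stronger inhibition), compound 3 gives 3160 nM, the highest number of the three: compound 1 gives a number lower by a 3.3-fold higher number from compound 1 to compound 3 (0.52 log units; beyond the scatter) and compound 2 lower still by a 33-fold higher number from compound 2 to compound 3 (1.52 log units; beyond the scatter), while the step of a 10-fold lower number from compound 1 to compound 2 (1.00 log units; beyond the scatter) shows how much the amino group gains over methoxy.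

Compound 4 `CC(C)(C)c1ccc(S(=O)(=O)Nc2ccc(Cl)cc2-c2c(O)ccc[n+]2[O-])cc1` has not been measured. It differs from compound 3 by a group of 8 heavy atoms (5 carbon, 1 nitrogen, 2 oxygen; one six-membered aromatic ring with 1 hetero atom) in place of a group of 8 heavy atoms (6 carbon, 2 nitrogen; one six-membered aromatic ring with 1 hetero atom), on an aromatic carbon, on an aromatic carbon of a six-membered aromatic ring of carbon only, ortho to a large group and meta to a chloro group. For the measured compounds named here, no measured step covers this swap of the whole ring group; the three steps at hand only replace one substituent on that ring, and they range from modest to large. Since compound 3 stands at the weak end, the estimate for compound 4 is a modest move to a lower number, a 3.2-fold lower number from compound 3 to compound 4 (0.50 log units; beyond the scatter), giving an expected 1000 nM in the range 200 nM to 5000 nM.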

Compound 4, half-maximal inhibitory concentration: 491 nM
Compound 4: middle estimate off by 2.0-fold (0.31 log units), on the high side; low and high end bracket the measured number.
By their numbers in this assay, from the lowest: compound 2; then compounds 4 and 1 (each within the scatter of the next); then compound 3.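

In this assay, exchanging the whole ring group on the aromatic carbon ortho to a large group moves the number even though the leaving and entering groups match in heavy-atom count, hydrogen-bond donors, hydrogen-bond acceptors and net charge: the change gives a 6.4-fold lower number from compound 3 to compound 4 (0.81 log units; beyond the scatter). This new group does not match the amino group, as a 5.2-fold higher number from compound 2 to compound 4 (0.71 log units; beyond the scatter) shows, while a 2.0-fold lower number from compound 1 to compound 4 (0.29 log units; within the scatter) lies within the scatter, so it cannot be told apart from the methoxy group. No measurement on hand bears on why these groups differ.

The compounds shown do not separate the contribution of the hydroxy group in compound 4 from that of its N-oxide oxygen. On these data alone, it also remains open whether a methylamino group or a carboxylic acid on the same ring would hold the number of compound 2 at 95 nM.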